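A few compounds are considered here, and "the series" means these few. Any claim that something is new, unique, unknown or untested is made for them only; others in the source may bear on it.

Working notes on the series. In a functional assay on KBVIN cells (Homo sapiens) for antiproliferative activity, read by sulforhodamine B assay, with a stated time of 3 days (a higher number here means that more compound is needed for the effect, a lower number that less compound is needed), compound 1 (`CCC1=C(O)c2c(oc(-c3ccc(OC)cc3)cc2=O)C(CC)(CC)C1=O`) gives 0.68 uM and compound 2 (`CCC1=C(O)c2c(oc(-c3ccc(OC)c(C)c3C)cc2=O)C(CC)(CC)C1=O`) gives 0.28 uM. Compound 2 thus holds the lower of the two numbers, and its gap to compound 1 lies beyond the scatter. For the measured compounds named here, no measured pair differs in one place only, so no single structural change has yet been read directly.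

The next compound, compound 3 (`CCC1=C(O)c2c(oc(-c3ccc(O)c(C)c3C)cc2=O)C(CC)(CC)C1=O`), departs from compound 2 at one point: hydrogen in place of methyl on an oxygen on an aromatic ring. This puts hydrogen in place of methyl on an oxygen on an aromatic ring, which reads as methoxy to hydroxy.

Going by the values given here, with no measured precedent for this change, the expectation is a judgement. It starts from compound 2 at 0.28 uM and leans towards a moderate rise in this assay, meaning that more compound would be needed for the effect. The estimated size of the change is a 3.6-fold higher number from compound 2 to compound 3 (0.55 log units; beyond the scatter), and a result within the scatter would not be surprising. The expected value for compound 3 is 1 uM, with an estimated range of 0.3 uM to 4.5 uM.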

Compound 3, concentration for half-maximal effect: 2.75 uM
Compound 3: middle estimate off by 2.8-fold (0.44 log units), on the low side; low and high end bracket the measured number.
By their numbers in this assay, from the lowest: compound 2; then compound 1; then compound 3.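

Methoxy to hydroxy is the first change in the series that can be read in one place: this assay shows a 9.8-fold higher number from compound 2 to compound 3 (0.99 log units; beyond the scatter) on going from methyl to hydrogen on an oxygen on an aromatic ring, so the number at this position responds strongly to that methyl. The wider exchange of 4-methoxyphenyl for 4-hydroxy-2,3-dimethylphenyl gives a 4.0-fold higher number from compound 1 to compound 3 (0.61 log units; beyond the scatter) in the same assay, so the two added ring methyls do not keep the number low once the methyl on oxygen is gone. The data shown carry no independent measurement that would explain the size of either step.

Going by these compounds, whether ethoxy, a longer alkoxy chain or an amine at this position would match or improve on compound 2 remains open. Also open, on these data alone, is how much of the gap between compound 1 and compound 3 belongs to the ring methyls and how much to the hydroxy, as the two changes are read here only together.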